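Working notes on compound 4, an unmeasured analogue

A few compounds are considered here, and "the series" means these few. Any claim that something is new, unique, unknown or untested is made for them only; others in the source may bear on it.

Values come from a functional assay on OVCAR-3 cells (Homo sapiens) for antiproliferative activity, read by MTT assay, with a stated time of 24 h; a higher number here means a weaker inhibitor, a lower number a stronger inhibitor.

compound 1 `O=C(NNC(=O)c1cccc(NS(=O)(=O)c2cnc(O)nc2O)c1)c1cccc(Cl)c1`: 13500 nM
compound 2 `O=C(NNC(=O)c1ccccc1F)c1cccc(NS(=O)(=O)c2cnc(O)nc2O)c1`: 10800 nM
compound 3 `O=C(NNC(=O)c1ccccc1NS(=O)(=O)c1cnc(O)nc1O)c1cccc(Cl)c1`: 2080 nM

Compound 1 and compound 2 share a core and differ by 2-fluorophenyl in place of 3-chlorophenyl on a carbonyl carbon; this gave a 1.3-fold lower number from compound 1 to compound 2 (0.10 log units; within the scatter). Compound 3 has the lowest number of the three; its gaps to compound 2 and to compound 1 lie beyond the scatter. The difference between the core of compound 3 and the core of compound 1 is not broken down here.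

Compound 4 `O=C(NNC(=O)c1ccccc1NS(=O)(=O)c1cnc(O)nc1O)c1ccccc1F` has not yet been measured. It differs from compound 3 by 2-fluorophenyl in place of 3-chlorophenyl on a carbonyl carbon. The place of the change is described in the same words for both pairs, so this is the same change that turned compound 1 into compound 2.

The step from compound 3 to compound 4 is expected to be a 1.2-fold lower number from compound 3 to compound 4 (0.09 log units; within the scatter), small and within scatter, because a 1.3-fold lower number from compound 1 to compound 2 (0.10 log units; within the scatter) was itself within scatter. Compound 4 is therefore estimated at 1700 nM in this assay, with a likely range from 700 nM to 4200 nM.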

Compound 4, half-maximal inhibitory concentration: 15300 nM
Beside the measured number, compound 4's estimate is 9.0-fold (0.95 log units) below it, and the stated range ends below it.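

In this assay, placing 2-fluorophenyl on the carbonyl carbon in place of 3-chlorophenyl gave a 7.4-fold higher number from compound 3 to compound 4 (0.87 log units; beyond the scatter), and the two steps for this change disagree: the same change on two cores in this assay, a 1.3-fold lower number (0.10 log units; within the scatter) from compound 1 to compound 2 and a 7.4-fold higher number (0.87 log units; beyond the scatter) from compound 3 to compound 4, 9.2-fold (0.96 log units) apart, beyond the scatter of two such steps

In this series, then, the size of this change depends on the core that carries it, and the step measured on the core of compound 1 did not predict the step on the core of compound 3. Among these compounds, this does not show which difference between the two cores is responsible, and with only two cores it gives no general rule for others.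

The compounds shown leave open whether the chlorine-to-fluorine exchange or the different place of the halogen on the ring accounts for the step from compound 3 to compound 4. 2-Chlorophenyl and 3-fluorophenyl on both cores would separate the two, and an unsubstituted phenyl would show how each halogen compares with hydrogen on each core.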